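Carbamoyl on the hydroxymethyl oxygen of compound 1

This account rests on a few compounds, and the source may have more. Where it says the series, first, only, none or still open, it means among the compounds named here.

Measured in a functional assay on V79-379A cells (Cricetulus griseus) for cytotoxicity, read by MTT assay, in the presence of a further agent that is not named here; on this read-out lower numbers stand for stronger inhibition and higher numbers for weaker inhibition:
- compound 1 `COC1=CC(=O)c2c(c(CO)cn2C)C1=O`: 220000 nM
- compound 2 `COC1=CC(=O)c2c(c(CO)c(C3CC3)n2C)C1=O`: 540000 nM

Compound 1 holds the lower of the two numbers in this assay. Compound 3 `COC1=CC(=O)c2c(c(COC(N)=O)cn2C)C1=O` differs from it by carbamoyl in place of hydrogen on an oxygen on a saturated carbon. Within the data shown here, only one measured step is available, and it bears on this change loosely: a 2.5-fold higher number from compound 1 to compound 2 (0.39 log units; beyond the scatter), a different change at a different place. It gives a scale and no direction, so a lower number is only tentatively expected. The expected step is a 3.1-fold lower number from compound 1 to compound 3 (0.50 log units; beyond the scatter). Compound 3 is estimated at 70000 nM, with an expected range of 10000 nM to 300000 nM.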

Compound 3, half-maximal inhibitory concentration: 3000 nM
Compound 3: the middle estimate sits 23-fold (1.37 log units) above what was measured, and the stated range ends above it.
By their numbers in this assay, from the lowest: compound 3; then compound 1; then compound 2.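

In this assay the hydroxymethyl oxygen proves a far more responsive place than the aromatic carbon: carbamoyl in place of hydrogen gives a 73-fold lower number from compound 1 to compound 3 (1.87 log units; beyond the scatter) and so outweighs the cyclopropyl change, which gives a 2.5-fold higher number from compound 1 to compound 2 (0.39 log units; beyond the scatter) in the opposite direction. No evidence in hand accounts for the size of this step. Still open, as far as these compounds go, is whether an acetyl group or a methylcarbamoyl group on the same oxygen, or an amine replacing that oxygen, would give a step of similar size. Also open, from the compounds shown here alone, is how cyclopropyl and carbamoyl behave when combined on the shared core.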